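Swapping ethyl for cyclohexyl on the amine of compound 1

The source may report more compounds than this note shows. Statements on the series, on what has been measured and on what is new or still open speak of the compounds shown alone.

Compound 1 `CCN(C)CCCOc1ccc2cc(NC(=O)c3ccc(O)c(CC=C(C)C)c3)c(=O)oc2c1C` is one of three closely related compounds tested in a functional assay on SK-BR-3 cells (Homo sapiens) for antiproliferative activity (on this read-out higher numbers stand for weaker inhibition and lower numbers for stronger inhibition), and in that assay compound 1 gives 730 nM. Compound 2 `CC(C)=CCc1cc(C(=O)Nc2cc3ccc(OCCCNC(C)C)c(C)c3oc2=O)ccc1O` gives 750 nM, and compound 3 `COC(=O)CNCCCOc1ccc2cc(NC(=O)c3ccc(O)c(CC=C(C)C)c3)c(=O)oc2c1C` gives 1060 nM. Compound 1 has the lowest of the three numbers, but its steps to the other two are within the scatter: a 1.0-fold higher number from compound 1 to compound 2 (0.01 log units; within the scatter) and a 1.5-fold higher number from compound 1 to compound 3 (0.16 log units; within the scatter). Compound 4 `CC(C)=CCc1cc(C(=O)Nc2cc3ccc(OCCCN(C)C4CCCCC4)c(C)c3oc2=O)ccc1O` has not yet been measured. It differs from compound 1 in one place: cyclohexyl in place of ethyl on an amine nitrogen. The two measured steps from compound 1 also change the group on this amine nitrogen, and neither moved the number beyond the scatter. The change to compound 4 is of the same kind, so no step beyond the scatter is expected in this assay, and the expected step is a 1.1-fold higher number from compound 1 to compound 4 (0.04 log units; within the scatter). Compound 4 is therefore estimated to give about 800 nM, most likely between 350 nM and 1800 nM.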

Compound 4, half-maximal inhibitory concentration: 970 nM
For compound 4 the middle estimate is 1.2-fold (0.08 log units) below the measured one; low and high end bracket the measured number.
By their numbers in this assay, from the lowest: compounds 1, 2, 4 and 3 (each within the scatter of the next).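

In this assay, within the data shown here, a ring now sits on this amine nitrogen for the first time: cyclohexyl, with 6 heavy atoms, replaces ethyl, with 2, and the result is a 1.3-fold higher number from compound 1 to compound 4 (0.12 log units; within the scatter) with no step beyond the scatter. The comparisons with the other two amines read the same way, with a 1.3-fold higher number from compound 2 to compound 4 (0.11 log units; within the scatter) and a 1.1-fold lower number from compound 3 to compound 4 (0.04 log units; within the scatter), so the open-chain groups and this carbon ring all lie within the scatter of one another here. No measurement shown gives a reason for this sameness.

From the compounds shown here alone, it remains open whether a morpholine on this nitrogen, a carboxylic acid in place of the methyl ester of compound 3, or a longer chain to the amine would move the number beyond the scatter.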